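Removing the aminocarbamoyl from compound 1

This account rests on a few compounds, and the source may have more. Where it says the series, first, only, none or still open, it means among the compounds named here.

Compound 1 `Cc1n[nH]c2c1C(c1ccc(N(C)C)cc1)C(C(=O)NN)=C(N)N2` gives the highest number of the two measured, 51300 nM in a functional assay on HeLa cells (Homo sapiens) for cytotoxicity, read by MTT assay, with a stated time of 48 h; a higher number here means a weaker inhibitor, a lower number a stronger inhibitor; compound 2 `Cc1n[nH]c2c1C(c1ccc(N(C)C)cc1)C(C(=O)NNc1cc([N+](=O)[O-])ccc1[N+](=O)[O-])=C(N)N2` gives 8520 nM there. Among the measured compounds shown here, the one measured step, a 6.0-fold lower number from compound 1 to compound 2 (0.78 log units; beyond the scatter), enlarges the group on the amine nitrogen. Compound 3 `Cc1n[nH]c2c1C(c1ccc(N(C)C)cc1)C=C(N)N2` goes the other way: hydrogen in place of aminocarbamoyl on a double-bonded ring carbon. For the measured compounds named here, no measured step removes this group, so the direction rests on compound 1 being the weaker partner after its only step. Compound 3 is expected to give 80000 nM, within 25000 nM to 250000 nM, an estimated step of a 1.6-fold higher number from compound 1 to compound 3 (0.19 log units; within the scatter).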

Compound 3, half-maximal inhibitory concentration: 27400 nM
The estimate for compound 3 lay 2.9-fold (0.47 log units) above the measured number, within the range that was stated.
By their numbers in this assay, from the lowest: compound 2; then compounds 3 and 1 (each within the scatter of the next).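

In this assay, hydrogen in place of aminocarbamoyl on the double-bonded ring carbon gives a 1.9-fold lower number from compound 1 to compound 3 (0.27 log units; within the scatter), so the group can be removed entirely without a change beyond the scatter. Within this pair, the number therefore does not depend on the aminocarbamoyl being present, whereas substitution on its amine nitrogen gives a 6.0-fold lower number from compound 1 to compound 2 (0.78 log units; beyond the scatter). No measurement available here explains either step.

As far as these compounds go, it remains open how a carboxylic acid, a methyl ester or a nitrile on this ring carbon would compare with hydrogen. Also open, from the compounds shown here alone, is whether any such group would give a step beyond the scatter.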